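Sulfonyl variation and cytotoxicity in a matched series

The source may report more compounds than this note shows. Statements on the series, on what has been measured and on what is new or still open speak of the compounds shown alone.

Compound 1, `CNS(=O)(=O)c1cn(Cc2nc3cc(Cl)ccc3n2CCCS(C)(=O)=O)c2ccccc12`: > 100000 nM (a limit)
Compound 2, `CN(C)S(=O)(=O)c1cn(Cc2nc3cc(Cl)ccc3n2CCCS(C)(=O)=O)c2ccccc12`: > 100000 nM (a limit)

Both measured compounds were tested in an ADME assay on HEp-2 cells (Homo sapiens) for cytotoxicity, with a stated time of 4 days; on this read-out higher numbers stand for lower toxicity in this test and lower numbers for higher toxicity in this test. Compound 1 gives only the limit > 100000 nM, which the assay could not resolve into a number. Compound 2 likewise gives only the limit > 100000 nM. Going by the values given here, the one measured step, methyl in place of hydrogen on a sulfonamide nitrogen, is a step that the two limits leave unreadable from compound 1 to compound 2; its size cannot be read because both ends sit at the limit of > 100000 nM in this assay, at which 2 of the 2 values shown sit.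

Compound 3, `CC(C)S(=O)(=O)c1cn(Cc2nc3cc(Cl)ccc3n2CCCS(C)(=O)=O)c2ccccc12`, differs from compound 2 by isopropyl in place of dimethylamino on a sulfonyl sulfur. Among the compounds with values here, no measured step bears directly on this exchange, and the single measured step, a step that the two limits leave unreadable from compound 1 to compound 2, offers no readable size to carry over. What the two measured compounds do show is that neither exchange at the sulfonyl group so far has brought toxicity within the measurable window.

The expected step in this assay is therefore a number no higher from compound 2 to compound 3 (the limit leaves the size open), none beyond the scatter. Compound 3 is expected to remain at the limit, with an estimate of 100000 nM and a range from 30000 nM to 300000 nM.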

Compound 3, half-maximal cytotoxic concentration: > 100000 nM
Compound 3 ended at the assay's limit; the forecaster's own chance of this, stated with the estimate: 80%; the middle value sits exactly at the limit.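

No new step can be read from compound 3: its comparisons with compound 1 and compound 2 in this assay all end at a limit of the assay and not at a number: the limit of > 100000 nM in this assay, at which 3 of the 3 values shown sit.

Still open, as far as these compounds go, is whether compound 1, compound 2 and compound 3 differ from one another in toxicity in this test at all.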